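The source may report more compounds than this note shows. Statements on the series, on what has been measured and on what is new or still open speak of the compounds shown alone.

Compound 1 `CN(Cc1ccccc1)C(=O)C1CCN(C(=O)c2ccc(S(C)(=O)=O)c([N+](=O)[O-])c2)CC1` and compound 2 `CN(Cc1ccccc1F)C(=O)C1CCN(C(=O)c2ccc(S(C)(=O)=O)c([N+](=O)[O-])c2)CC1` share one core; compound 3 `CN(CC(=O)N1CCN(c2ccc(F)cc2)CC1)C(=O)c1ccc(S(C)(=O)=O)c([N+](=O)[O-])c1` carries another, and the difference between the two cores is not broken down here. In an assay on isolated protein for inhibition of vitamin D3 receptor (Homo sapiens), read by fluorescence polarization (a lower number here means a stronger inhibitor, a higher number a weaker inhibitor), compound 1 gives > 60000 nM, a limit of the assay. In this assay compound 2 gives > 60000 nM, also a limit. In this assay compound 3 gives > 60000 nM, again a limit. The change hydrogen in place of fluoro on an aromatic carbon yields a step that the two limits leave unreadable from compound 2 to compound 1, unreadable because of the limit of > 60000 nM in this assay, at which 3 of the 3 values shown sit. Compound 4 `CN(CC(=O)N1CCN(c2ccccc2)CC1)C(=O)c1ccc(S(C)(=O)=O)c([N+](=O)[O-])c1` arises from compound 3 by hydrogen in place of fluoro on an aromatic carbon, the same kind of change, but placed para to a large group rather than ortho to a large group. The expectation for compound 4 rests on compound 3, whose value > 60000 nM is a limit. The step that the limit leaves unreadable from compound 3 to compound 4 is expected to stay within the scatter. Compound 4 is estimated at 90000 nM in this assay.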

Compound 4, half-maximal inhibitory concentration: > 60000 nM
Compound 4 ended at the assay's limit (the forecaster's own chance of this, stated with the estimate: 85%); the middle value lies beyond the limit too.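

No step can be read from compound 3 to compound 4, because both values are limits of the assay: the limit of > 60000 nM in this assay, at which 4 of the 4 values shown sit. The compounds shown leave open whether any change in this series gives a readable value in this assay at all.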